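Double bond in the chain of compound 2

A few compounds are considered here, and "the series" means these few. Any claim that something is new, unique, unknown or untested is made for them only; others in the source may bear on it.

In an ADME assay on cells (Fibroblast, Homo sapiens) for antiproliferative activity, read by sulforhodamine B assay, with a stated time of 48 h (on this read-out lower numbers stand for stronger inhibition and higher numbers for weaker inhibition), compound 1 `CCCCCCCCCCCCCCNC(=O)[C@@H]1CSC(c2ccc(NC(C)=O)cc2)N1` gives 3600 nM. Compound 2 `CCCCCCCCCCCCCCCCCCNC(=O)[C@@H]1CSC(c2ccc(NC(C)=O)cc2)N1` gives > 60000 nM, which is a limit of the assay and not a number. Its standing is therefore (the limit of > 60000 nM in this assay, at which 1 of the 2 values shown sits). Compound 3 `CCCCCCCCC/C=C\CCCCCCCNC(=O)[C@@H]1CSC(c2ccc(NC(C)=O)cc2)N1` differs from compound 2 by a group of 11 heavy atoms (11 carbon; no ring) in place of a group of 11 heavy atoms (11 carbon; no ring), on a saturated chain carbon, seven bonds along the chain from an amide-type nitrogen, on a saturated chain carbon, seven bonds along the chain from an amide-type nitrogen. Among the compounds with values here, the only measured step that bears on this, an at least 16-fold higher number from compound 1 to compound 2 (1.22 log units; beyond the scatter), is large but introduces no double bond, so it guides only loosely. A modest move to a lower number is expected in this assay, though the result may stay at the limit. The expected step is an at least 3.0-fold lower number from compound 2 to compound 3 (0.47 log units; beyond the scatter). For compound 3 the estimated value is 20000 nM, with an expected range of 4000 nM to 60000 nM.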

Compound 3, half-maximal inhibitory concentration: 10600 nM
Compound 3: the middle estimate sits 1.9-fold (0.28 log units) above what was measured, and the stated range covers the measured number.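

A double bond in the chain, seven bonds along the chain from an amide-type nitrogen, brings the series back to a measurable number with the heavy-atom count of the group unchanged: an at least 5.6-fold lower number from compound 2 to compound 3 (0.75 log units; beyond the scatter). The value for compound 2 is a limit of the assay and not a number: the limit of > 60000 nM in this assay, at which 1 of the 3 values shown sits. The double bond does not recover the level of the shorter saturated chain: a 2.9-fold higher number from compound 1 to compound 3 (0.47 log units; beyond the scatter).

Still open, on these data alone, is whether a trans double bond, or a triple bond at the same place, would give a similar number. Also open, as far as these compounds go, is what a double bond would do in the tetradecyl chain of compound 1.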